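The compounds below may be only part of what the source reports. "The series", "measured", "known", "first", "only" and "open" are said of these compounds alone.

Compound 1 `COc1cc(O)c2c(c1O)C[C@]1(C)O[C@@H]1CC[C@@]1(C)O[C@@H]1C2=O` - 9900 nM
Compound 2 `COc1cc(O)c2c(c1O)C/C(C)=C\CC[C@@]1(C)O[C@@H]1C2=O` - 9700 nM

In an ADME assay on L929 cells (Mus musculus) for antiproliferative activity, read by WST assay, with a stated time of 5 days (a lower number here means a stronger inhibitor, a higher number a weaker inhibitor), compound 2 gives 9700 nM, and compound 1 gives 9900 nM. These two values lie within the scatter of each other. Compound 3 `COc1cc(O)c2c(c1O)[C@@H](O)/C(C)=C\CC[C@@]1(C)O[C@@H]1C2=O` carries hydroxy in place of hydrogen on a saturated ring carbon of compound 2: hydroxy in place of hydrogen on a saturated ring carbon. Going by the values given here, no measured step covers this change, so the expectation has no direct precedent. In this assay no step beyond the scatter is expected, and no firm direction. The expected change is a 1.2-fold lower number from compound 2 to compound 3 (0.08 log units; within the scatter). For compound 3 the estimated value is 8000 nM, with an expected range of 2500 nM to 25000 nM.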

Compound 3, half-maximal inhibitory concentration: 4000 nM
Compound 3: the middle estimate sits 2.0-fold (0.30 log units) above what was measured, within the range that was stated.
By their numbers in this assay, from the lowest: compound 3; then compounds 2 and 1 (each within the scatter of the next).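

In this assay, going by these compounds alone, hydroxy in place of hydrogen on this saturated ring carbon, next to the ring atom that bears a methyl group, gives a 2.4-fold lower number from compound 2 to compound 3 (0.38 log units; beyond the scatter) and so provides the first step beyond the scatter. The position is therefore not silent to substitution, though the step is modest and rests on this one pair. Nothing measured here accounts for the step. Hydroxy is the only group shown on this carbon, so whether an amine, a fluorine atom or a methoxy group there would move the number the same way remains open.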